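A few compounds are considered here, and "the series" means these few. Any claim that something is new, unique, unknown or untested is made for them only; others in the source may bear on it.

Compound 1, `CCCn1nc(-c2cccnc2)c2ccccc2c1=O`, is one of three close relatives of a shared core measured in an assay on isolated protein (Oryctolagus cuniculus) with Thromboxane-A synthase (Homo sapiens) as the target, tested at 1 uM; on this read-out higher numbers stand for more inhibition at the one concentration tested (going by the name of the read-out) and lower numbers for less inhibition. In that assay compound 1 gives 86%, the second highest of the three numbers. Compound 2, `CC(C)=CCn1nc(-c2cccnc2)c2ccccc2c1=O`, gives 94%, and the step of a number 8 percentage points higher from compound 1 to compound 2 (within the scatter) is within the scatter. Compound 3, `COCCn1nc(-c2cccnc2)c2ccccc2c1=O`, gives 55%, and here the step of a number 31 percentage points lower from compound 1 to compound 3 (beyond the scatter) is large, as is the step of a number 39 percentage points lower from compound 2 to compound 3 (beyond the scatter).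

Compound 4, `O=C(O)CCCn1nc(-c2cccnc2)c2ccccc2c1=O`, has not yet been measured in this assay. It differs from compound 1 by carboxy in place of hydrogen on a saturated chain carbon, three bonds along the chain from an aromatic nitrogen.

Among the compounds with values here, the step that bears most on this change is the one from compound 1 to compound 3, where a methoxy took the place of a methyl on the chain and the inhibition fell by a number 31 percentage points lower from compound 1 to compound 3 (beyond the scatter). The step from compound 1 to compound 2, a change within the scatter, shows that with a carbon-only extension of the chain the number stays level. Adding oxygen to the chain is the closer precedent, so a fall beyond the scatter is expected, though of uncertain size. The estimate for compound 4 is 55%, with a range from 30% to 80%, which means an expected step of a number 31 percentage points lower from compound 1 to compound 4 (beyond the scatter).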

Compound 4, a percentage reported as inhibition, at one concentration (the size of the read-out at that concentration, not a potency): 73%
The estimate for compound 4 lay 18 percentage points below the measured number; low and high end bracket the measured number.
By their numbers in this assay, from the lowest: compound 3; then compound 4; then compounds 1 and 2 (each within the scatter of the next).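

Carboxy three bonds along the chain from an aromatic nitrogen lowers inhibition in this assay only modestly, with a number 13 percentage points lower from compound 1 to compound 4 (beyond the scatter) as the step, so this position can carry that group and keep much of the inhibition seen with the plain propyl chain. Oxygen atoms on this chain therefore do not bring one fixed loss, since the exchange of methoxy for carboxymethyl gives a number 18 percentage points higher from compound 3 to compound 4 (beyond the scatter) and so places the 3-carboxypropyl chain clearly above the methoxy-bearing chain. The 3-methylbut-2-enyl-type chain of compound 2, written here as 2-methylprop-1-en-1-yl on the chain carbon, keeps its lead, with a number 21 percentage points lower from compound 2 to compound 4 (beyond the scatter) as a further modest step, so the carboxy chain does not match the carbon-only chain with the double bond.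

Still open, as far as these compounds go, is how much depends on the length of the chain that bears the carboxylic acid, since a 2-carboxyethyl or 4-carboxybutyl group on the aromatic nitrogen might fall on either side of compound 4, and whether an amine or a primary amide at the chain end would behave like carboxy. Nothing measured here accounts for why these chains differ as they do.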